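The source may report more compounds than this note shows. Statements on the series, on what has been measured and on what is new or still open speak of the compounds shown alone.

Among the compounds with values here, compound 2 `CCN1CCN(c2cc(C)c3cc(NC(=O)c4cccnc4)ccc3n2)CC1` has the highest of the two numbers so far in a functional assay on MCF7 cells (Homo sapiens) for antiproliferative activity, read by MTT assay, with a stated time of 72 h (a lower number here means a stronger inhibitor, a higher number a weaker inhibitor), giving 26600 nM. Within the data shown here, its nearest neighbour is compound 1 `CCN1CCN(c2cc(C)c3cc(NC(=O)c4ccccc4C)ccc3n2)CC1`, which in this assay gives 10900 nM; the only measured step is a 2.4-fold higher number from compound 1 to compound 2 (0.39 log units; beyond the scatter), and that step lies beyond the scatter. Compound 3 `CCN1CCN(c2cc(C)c3cc(NC(=O)c4ccc(Cl)c(Cl)c4)ccc3n2)CC1` differs from compound 2 in one place: 3,4-dichlorophenyl in place of pyridin-3-yl on a carbonyl carbon. The measured step bears on this change only in part, since it exchanged one carbon-only ring for a pyridin-3-yl, whereas here the pyridin-3-yl gives way to another carbon-only ring carrying two chlorines. Among the measured compounds shown here, on that basis a modest move back toward the number of compound 1 is expected, though the chlorines have no measured counterpart here. Compound 3 is therefore estimated at 10000 nM, with a range from 3500 nM to 30000 nM, an expected step of a 2.7-fold lower number from compound 2 to compound 3 (0.42 log units; beyond the scatter).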

Compound 3, half-maximal inhibitory concentration: 1380 nM
Compound 3: middle estimate off by 7.2-fold (0.86 log units), on the high side; measured number below the stated range.
By their numbers in this assay, from the lowest: compound 3; then compound 1; then compound 2.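

In this assay the place on the carbonyl carbon proves able to carry a much lower number than the first two compounds suggested: 3,4-dichlorophenyl in place of pyridin-3-yl gives the large step (a 19-fold lower number from compound 2 to compound 3 (1.29 log units; beyond the scatter)). The change is not simply the loss of the ring nitrogen, since 3,4-dichlorophenyl in place of 2-methylphenyl, one carbon-only ring for another, also lowers the number (a 7.9-fold lower number from compound 1 to compound 3 (0.90 log units; beyond the scatter)). Compound 3 thus stands as the strongest inhibitor of the three, and what is on the carbon-only ring matters as well as the ring itself. Nothing measured here accounts for this result. The compounds shown leave open whether a single chlorine, as in 3-chlorophenyl or 4-chlorophenyl, would give a similar number. They also leave open whether 3,4-dimethylphenyl would do the same.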